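Flipping One Double Bond in a Cytotoxic Chain

The source may hold more compounds than are shown below. What is called first, only, known or untested is meant among the compounds shown, and "the series" means these compounds.

Three open-chain compounds have been tested in a functional assay on P388 cells (Mus musculus) for cytotoxicity (on this read-out higher numbers stand for weaker inhibition and lower numbers for stronger inhibition), a cytotoxicity read-out on mouse leukaemia cells. Compound 1 `CC(C)=CCCC(C)/C=C/C=C(\C)C=O` carries a terminal aldehyde and in this assay compound 1 gives 0.5 ug/mL. Compound 2 `C=C/C(C)=C/C=C/C(C)(O)CCC=C(C)C` replaces that end with a tertiary alcohol, and in this assay compound 2 gives 2.5 ug/mL. Compound 3 `C=C/C(C)=C\C=C\C(C)CC(=O)CC(C)C` keeps the same diene end but carries a ketone further along the chain; in this assay compound 3 gives 2.5 ug/mL. On these figures compound 3 sits level with compound 2, the two of them sharing the highest number of the three, while compound 1 sits well apart with the lowest.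

The next compound, compound 4 `C=C/C(C)=C/C=C/C(C)CC(=O)CC(C)C`, is the geometric twin of compound 3. The two compounds have the same atoms and bonds; at least one stereo element is drawn with a configuration in one of them and without one in the other: 1 of 3 stereo elements differ (the two compounds have the same atoms and bonds; at least one stereo element is drawn with a configuration in one of them and without one in the other: 1 of 3 stereo elements differ; a double bond is drawn Z in compound 3 and E in compound 4). Among the compounds with values here, no measured pair here isolates such a geometric change, so there is no step to lean on. Given that compound 3 gives 2.5 ug/mL, compound 4 is expected to land close to it, with a step from compound 3 to compound 4 of no change at the digits printed from compound 3 to compound 4 (within the scatter) or nothing beyond the scatter. Compound 4 is therefore estimated at 2.5 ug/mL, within 1 ug/mL to 6 ug/mL.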

Compound 4, half-maximal inhibitory concentration: 2.5 ug/mL
Compound 4: middle estimate and measured number agree at the digits printed; measured number inside the range.
By their numbers in this assay, from the lowest: compound 1; then compounds 2, 3 and 4 (each within the scatter of the next).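

In this assay, within the data shown here, turning the double bond from Z in compound 3 to E in compound 4 gives no change at the digits printed from compound 3 to compound 4 (within the scatter), and this is the first pair that differs in one place only. Among these compounds, at this position, and on the ketone chain that the two compounds share, the geometry of this double bond therefore leaves the read-out unmoved, which the earlier compounds, differing from one another in more than one place, could not show. That reading carries one reservation, since the comparison rests on how the two structures are drawn: the fact that one of compounds 3 and 4 is drawn with a defined configuration and the other without, at the place where they differ.

The compounds shown leave open whether the same change of geometry would be equally silent on a chain ending in the tertiary alcohol of compound 2, or on the aldehyde-bearing chain of compound 1, which gives 0.5 ug/mL in this assay. They also leave open what the number would do if an amine or a carboxylic acid took the place of the ketone on the chain of compound 4.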